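A few compounds are considered here, and "the series" means these few. Any claim that something is new, unique, unknown or untested is made for them only; others in the source may bear on it.

Measured in an ADME assay on C1866 cells (Homo sapiens) for cytotoxicity, read by MTT assay, with a stated time of 72 h; on this read-out lower numbers stand for an effect already at smaller amounts and higher numbers for an effect only at larger amounts of compound:
compound 1 `CC(C)c1c(CC2CCCCC2)nc(SCC(=O)c2ccccc2O)[nH]c1=O` — 1.95 nM
compound 2 `CC(C)c1c(CC2CCCCC2)nc(SCC(=O)c2ccccc2)[nH]c1=O` — 0.025 nM
compound 3 `CCc1c(CC2CCCCC2)nc(SCC(=O)c2ccccc2)[nH]c1=O` — 0.012 nM

Compound 2 stands second highest of the three numbers in this assay; its nearest neighbour is compound 3 (a 2.1-fold lower number from compound 2 to compound 3 (0.32 log units; beyond the scatter)), its furthest compound 1 (a 78-fold lower number from compound 1 to compound 2 (1.89 log units; beyond the scatter)).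

Compound 4 `CC(C)c1c(Cc2ccccc2)nc(SCC(=O)c2ccccc2)[nH]c1=O` has not yet been measured. It differs from compound 2 in one place: phenyl in place of cyclohexyl on a saturated chain carbon bound to an aromatic carbon.

Neither measured step touches this position. The step of a 78-fold lower number from compound 1 to compound 2 (1.89 log units; beyond the scatter) concerns a hydroxy on the other aromatic ring, and the step of a 2.1-fold lower number from compound 2 to compound 3 (0.32 log units; beyond the scatter) concerns the substituent on the core. Nothing in the series therefore speaks directly to the exchange of cyclohexyl for phenyl, and no direction can be read from the data. The working expectation is a step that stays within or only slightly beyond the scatter, in either direction, with wide uncertainty.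

Compound 4 is expected near 0.03 nM in this assay, within 0.008 nM to 0.12 nM. The step of a 1.2-fold higher number from compound 2 to compound 4 (0.08 log units; within the scatter) this estimate implies is expected to be small.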

Compound 4, half-maximal effective concentration: 14 nM
For compound 4 the middle estimate is 470-fold (2.67 log units) below the measured one; measured number above the stated range.
By their numbers in this assay, from the lowest: compound 3; then compound 2; then compound 1; then compound 4.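

In this assay, among the compounds shown here, the position carrying the cyclohexylmethyl group proves highly sensitive: the exchange to benzyl gives a 560-fold higher number from compound 2 to compound 4 (2.75 log units; beyond the scatter) and is the largest step so far. The two groups match in heavy atoms and in hydrogen-bond donors and acceptors, so the computed difference between them lies in whether the six-membered ring is aromatic or non-aromatic. Nothing at hand accounts for the size of this step.

The compounds shown leave open whether the same exchange has a comparable effect on the core of compound 3 or alongside the hydroxy of compound 1. They also leave open how other groups on this saturated chain carbon would read out, such as cyclopentyl, a piperidine ring or a longer alkyl chain, so a single aromatic example marks no general trend.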